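Cytotoxicity notes on a bicyclic nucleoside sulfonate series

This account rests on a few compounds, and the source may have more. Where it says the series, first, only, none or still open, it means among the compounds named here.

Measured so far:
- compound 1 `Cc1cn([C@@H]2O[C@H](CO[Si](C)(C)C(C)(C)C)[C@@]3(OS(=O)(=O)C=C3NCCC(N)=O)[C@H]2O[Si](C)(C)C(C)(C)C)c(=O)n(C)c1=O`: 20000 nM
- compound 2 `Cc1cn([C@@H]2O[C@H](CO[Si](C)(C)C(C)(C)C)[C@@]3(OS(=O)(=O)C=C3NCCC(=O)O)[C@H]2O[Si](C)(C)C(C)(C)C)c(=O)n(C)c1=O`: 11500 nM
- compound 3 `Cc1cn([C@@H]2O[C@@H]3COC4(O)CS(=O)(=O)O[C@@]34[C@H]2O)c(=O)[nH]c1=O`: 100000 nM

In a functional assay on MT4 cells (Homo sapiens) (a lower number here means that less compound is tolerated, a higher number that more compound is tolerated), compound 2 stands at the lowest of the three numbers. Within the data shown here, compound 1 is its nearest neighbour, and the only single-point step measured so far, a 1.7-fold lower number from compound 1 to compound 2 (0.24 log units; within the scatter), is within the scatter. Among the measured compounds shown here, compound 3 sits furthest away, at a number beyond the scatter from compound 2; no single-point step connects the two, so only their two values can be compared.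

Compound 4 `Cc1cn([C@@H]2O[C@H](CO[Si](C)(C)C(C)(C)C)[C@@]3(OS(=O)(=O)C=C3NCC(=O)C(=O)N3CCC3)[C@H]2O[Si](C)(C)C(C)(C)C)c(=O)n(C)c1=O` is not yet measured. It differs from compound 2 by ((azetidin-1-yl)carbonyl)carbonyl in place of carboxymethyl on a saturated chain carbon bound to an amine nitrogen. For the measured compounds named here, the one measured step, from the carbonyl amino group of compound 1 to the hydroxy group of compound 2, touched the same chain end and stayed within the scatter. Going by the values given here, the change to compound 4 is larger in what enters, and no measured pair shows a change of that kind, so the expectation is weakly founded. On the available evidence the step in this assay is expected to be a 1.3-fold higher number from compound 2 to compound 4 (0.12 log units; within the scatter), with no clear direction beyond the scatter.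

Compound 4 is therefore estimated at 15000 nM, range 6000 nM to 45000 nM.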

Compound 4, half-maximal cytotoxic concentration: 17400 nM
Compound 4: middle estimate off by 1.2-fold (0.06 log units), on the low side; the measured number falls inside the stated range.
By their numbers in this assay, from the lowest: compounds 2, 4 and 1 (each within the scatter of the next); then compound 3.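

In this assay, the replacement on a saturated chain carbon bound to an amine nitrogen is far larger than the earlier change at the chain end, yet neither new step leaves the scatter (a 1.5-fold higher number from compound 2 to compound 4 (0.18 log units; within the scatter); a 1.1-fold lower number from compound 1 to compound 4 (0.06 log units; within the scatter)). Carboxymethyl and carbamoylmethyl can thus each give way to ((azetidin-1-yl)carbonyl)carbonyl, with its four-membered non-aromatic ring and 0 hydrogen-bond donors, without any measurable separation of compound 1, compound 2 and compound 4. Across these three different chain ends, this assay shows no dependence on the end group at this position, a statement the single earlier step could support only for a much smaller change.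

From the compounds shown here alone, whether any chain end at this position can move the number beyond the scatter remains open, for example a chain ending in a primary amine or a longer chain carrying a piperidine amide. Compound 3, at 100000 nM, differs from the others in more than one place, so it gives no reading on this position or on the silyl groups of the shared core.

No supporting measurement bears on why the number stays flat across these chain ends.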